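The source may hold more compounds than are shown below. What is called first, only, known or untested is meant among the compounds shown, and "the series" means these compounds.

Compound 1 `CC(O)(CS(=O)(=O)c1ccc(Br)cc1)c1nc(-c2ccc([N+](=O)[O-])c(C(F)(F)F)c2)no1`: > 100000 nM
Compound 2 `CC(O)(CSc1ccc(F)cc1)c1nc(-c2ccccc2)no1`: > 100000 nM
Compound 3 `CC(O)(CS(=O)(=O)c1ccccc1)c1nc(-c2ccccc2)no1`: > 100000 nM

In a functional assay on DU-145 cells (Homo sapiens) for cytotoxicity, read by MTT assay (a higher number here means a weaker inhibitor, a lower number a stronger inhibitor), compound 1 gives only a limit, > 100000 nM, and no number. Compound 2 and compound 3 likewise reach only the limit of this assay. Compound 1 thus stands at the limit of > 100000 nM in this assay, at which 3 of the 3 values shown sit, with nothing to set it apart from the other two. Compound 4 `CC(O)(CS(=O)(=O)c1ccc(F)cc1)c1nc(-c2ccc([N+](=O)[O-])c(C(F)(F)F)c2)no1` differs from compound 1 by fluoro in place of bromo on an aromatic carbon, para to a large group. Going by the values given here, no measured pair shows what this change does in this assay. With every measured value at the limit, compound 4 is expected to stay at the limit too, so the step of a number no higher from compound 1 to compound 4 (the limit leaves the size open) is expected to be none beyond the scatter. Compound 4 is estimated at 100000 nM, within 50000 nM to 300000 nM.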

Compound 4, half-maximal inhibitory concentration: > 100000 nM
Compound 4: no number, only a limit (the forecaster's own chance of this, stated with the estimate: 85%); the middle value lies on the limit itself.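

Compound 1 and compound 4 both give only a limit in this assay, so no step can be read between them. The compounds shown leave open which structural change, if any, would yield a measurable value.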